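Swapping an aromatic hydroxamate linker for a flexible chain

The source may report more compounds than this note shows. Statements on the series, on what has been measured and on what is new or still open speak of the compounds shown alone.

Three compounds share a core and carry a hydroxamic acid on a linker attached through an amide. Compound 1 `CC(C)Oc1ccc(C(C)(C)O)cc1-c1cn(C)c(=O)c2[nH]c(C(=O)NCCCCCCC(=O)NO)cc12` and compound 2 `Cn1cc(-c2cc(C(C)(C)O)ccc2OC2CC2)c2cc(C(=O)NCCCCCCC(=O)NO)[nH]c2c1=O` carry the same chain-type linker and differ only in the group on the ether oxygen; in an assay on isolated protein for inhibition of protein deacetylase HDAC6 (Homo sapiens), read by fluorescence (a higher number here means a weaker inhibitor, a lower number a stronger inhibitor), compound 1 gives 5.4 nM and compound 2 gives 5.5 nM, a step of a 1.0-fold higher number from compound 1 to compound 2 (0.01 log units; within the scatter). Compound 3 `Cn1cc(-c2cc(C(C)(C)O)ccc2Oc2ccc(F)cc2F)c2cc(C(=O)NCc3ccc(C(=O)NO)cc3)[nH]c2c1=O` carries a benzyl-type linker instead and gives 15.6 nM, the highest of the three numbers, set apart from both others beyond the scatter.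

Compound 4 `Cn1cc(-c2cc(C(C)(C)O)ccc2Oc2ccc(F)cc2F)c2cc(C(=O)NCCCCCCC(=O)NO)[nH]c2c1=O` keeps the rest of compound 3 and changes only the linker: 5-(hydroxycarbamoyl)pentyl in place of 4-(hydroxycarbamoyl)phenyl on a saturated chain carbon bound to an amide-type nitrogen. Among the measured compounds shown here, no single measured step covers this change, but compound 1 and compound 2 hold the same chain as compound 4 and both sit well below compound 3, while the one measured step shows the ether group barely matters. A lower number is therefore expected for compound 4, with an estimated step of a 2.6-fold lower number from compound 3 to compound 4 (0.41 log units; beyond the scatter). Compound 4 is expected to give about 6 nM, within a range from 2.5 nM to 15 nM.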

Compound 4, half-maximal inhibitory concentration: 8.7 nM
For compound 4 the middle estimate is 1.5-fold (0.16 log units) below the measured one, within the range that was stated.
By their numbers in this assay, from the lowest: compounds 1, 2, 4 and 3 (each within the scatter of the next, the first and the last beyond it).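

In this assay, the linker change gives a 1.8-fold lower number from compound 3 to compound 4 (0.25 log units; within the scatter), so with 2,4-difluorophenyl on the ether oxygen, 5-(hydroxycarbamoyl)pentyl and 4-(hydroxycarbamoyl)phenyl cannot be told apart at this position. With the chain linker held constant, 2,4-difluorophenyl in place of cyclopropyl gives a 1.6-fold higher number from compound 2 to compound 4 (0.20 log units; within the scatter), and in place of isopropyl it gives a 1.6-fold higher number from compound 1 to compound 4 (0.21 log units; within the scatter), so the tolerance seen between the two small groups on that oxygen now extends, among these compounds, to a group with an aromatic ring, since both steps stay within the scatter. No supporting measurement bears on why these steps are so small.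

On these data alone, it remains open whether the 4-(hydroxycarbamoyl)phenyl linker would match the chain equally closely with isopropyl or cyclopropyl on the ether oxygen. Also open, as far as these compounds go, is how a longer chain in the linker, or a group such as a simple methyl or an unsubstituted phenyl on that oxygen, would read in this assay.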